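From Dimethylamino to Carboxy on a Shared Core

A few compounds are considered here, and "the series" means these few. Any claim that something is new, unique, unknown or untested is made for them only; others in the source may bear on it.

Compound 1 `O=C1Nc2ccccc2/C1=N/NC(=S)Nc1ccc(Cl)cc1`: 4990 nM
Compound 2 `O=C1Nc2ccccc2/C1=N/NC(=S)Nc1ccc(F)cc1`: 1920 nM
Compound 3 `CN(C)c1ccc(NC(=S)N/N=C2\C(=O)Nc3ccccc32)cc1`: 2320 nM

Within the data shown here, these three compounds were measured in a functional assay on KB-V1 cells (Homo sapiens) for cytotoxicity, read by MTT assay, with a stated time of 72 h (on this read-out lower numbers stand for stronger inhibition and higher numbers for weaker inhibition), and they differ in only one group. Compound 3 gives 2320 nM, which cannot be told apart from compound 2: the step is a 1.2-fold higher number from compound 2 to compound 3 (0.08 log units; within the scatter). Compound 1 has the highest number, with a clear gap of a 2.2-fold lower number from compound 1 to compound 3 (0.33 log units; beyond the scatter).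

The next compound to be tested is compound 4 `O=C1Nc2ccccc2/C1=N/NC(=S)Nc1ccc(C(=O)O)cc1`. It carries carboxy in place of dimethylamino on an aromatic carbon.

Three measured swaps on an aromatic carbon bear on this change. Besides the two steps already given, there is a 2.6-fold lower number from compound 1 to compound 2 (0.41 log units; beyond the scatter), which is also modest. Among the measured compounds shown here, none of the measured compounds carries a carboxy group, so these steps guide the expected size better than the direction. Since the largest of them, a 2.6-fold lower number from compound 1 to compound 2 (0.41 log units; beyond the scatter), is modest, a modest step is expected in this assay. Carboxy is a new kind of group in this set, so a higher number is tentatively expected, and the range is kept wide. The estimated step is a 2.6-fold higher number from compound 3 to compound 4 (0.41 log units; beyond the scatter). For compound 4 the estimated value is 6000 nM, with an expected range from 2000 nM to 25000 nM.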

Compound 4, half-maximal inhibitory concentration: > 50000 nM
Compound 4: only a limit was reported; the forecaster's own chance of this, stated with the estimate: 12%; middle value at least 8.3-fold (0.92 log units) from the limit.
By their numbers in this assay, from the lowest: compounds 2 and 3 (each within the scatter of the next); then compound 1. At a limit, above all of these: compound 4.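

In this assay compound 4 stands at a limit and not at a number: the limit of > 50000 nM in this assay, at which 1 of the 4 values shown sits. This makes the swap to carboxy, on an aromatic carbon para to a large group, by far the biggest change in the set, with an at least 21-fold higher number from compound 3 to compound 4 (1.33 log units; beyond the scatter), an at least 26-fold higher number from compound 2 to compound 4 (1.41 log units; beyond the scatter) and an at least 10-fold higher number from compound 1 to compound 4 (1.00 log units; beyond the scatter), all read against that limit. The earlier swaps among chloro, fluoro and dimethylamino gave only modest steps or steps within the scatter, so they made this position look forgiving, whereas compound 4 shows that the group placed here can matter a great deal in this cell test.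

The compounds shown include no methyl ester or primary amide at this position, so it stays open whether the loss belongs to the free carboxylic acid or would come with any carbonyl-bearing group here. Among these compounds, a hydroxymethyl group or a nitrile in the same place would also help to show how narrow the demand at this position is, and the single carboxy compound cannot settle that alone.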